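A few compounds are considered here, and "the series" means these few. Any claim that something is new, unique, unknown or untested is made for them only; others in the source may bear on it.

Compound 3 `N#CC1=C(N)Oc2c(c3nc4ccccc4nc3c3ccccc23)C12C(=O)N(Cc1cnnn1-c1ccc([N+](=O)[O-])cc1)c1ccccc12` stands at the edge of what a functional assay on HCT-116 cells (Homo sapiens) for antiproliferative activity, read by MTT assay, with a stated time of 48 h (a lower number here means a stronger inhibitor, a higher number a weaker inhibitor), can show: in this assay compound 3 gives > 50000 nM, which is a limit of the assay and not a number. Its two neighbours stand no differently. Compound 1 `N#CC1=C(N)Oc2c(c3nc4ccccc4nc3c3ccccc23)C12C(=O)N(Cc1cnnn1-c1ccc(F)cc1)c1ccccc12` gives > 50000 nM in this assay, likewise a limit. Compound 2 `N#CC1=C(N)Oc2c(c3nc4ccccc4nc3c3ccccc23)C12C(=O)N(Cc1cnnn1-c1ccc(Br)cc1)c1ccccc12` gives > 50000 nM in this assay, again a limit. All three values thus rest on (the limit of > 50000 nM in this assay, at which 3 of the 3 values shown sit), and the three steps among them, a step that the two limits leave unreadable from compound 1 to compound 2, a step that the two limits leave unreadable from compound 1 to compound 3 and a step that the two limits leave unreadable from compound 2 to compound 3, have no readable size, because the limit of > 50000 nM in this assay, at which 3 of the 3 values shown sit, hides whatever difference the aryl substituents may make.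

Compound 4 `N#CC1=C(N)Oc2c(c3nc4ccccc4nc3c3ccccc23)C12C(=O)N(Cc1cnnn1-c1cccc(S(N)(=O)=O)c1)c1ccccc12` differs from compound 3 in a single place: 3-sulfamoylphenyl in place of 4-nitrophenyl on an aromatic nitrogen. Of the measured steps, all three bear on changes of the same aryl substituent, and none could be read; no one of them offered a hint of a shift away from the limit. The expectation for the step from compound 3 to compound 4 in this assay is accordingly none that the assay could resolve, an estimated a number no higher from compound 3 to compound 4 (the limit leaves the size open). Compound 4 is therefore expected to remain at the limit, with an estimated value of 50000 nM. The estimated range for compound 4 runs from 20000 nM to 100000 nM.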

Compound 4, half-maximal inhibitory concentration: 11300 nM
The estimate for compound 4 lay 4.4-fold (0.65 log units) above the measured number; measured number below the stated range.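

In this assay, among the compounds shown here, the aryl group on the aromatic nitrogen of the five-membered ring gives the first readable change at this position, with the 3-sulfamoylphenyl group producing an at least 4.4-fold lower number from compound 3 to compound 4 (0.64 log units; beyond the scatter), an at least 4.4-fold lower number from compound 2 to compound 4 (0.64 log units; beyond the scatter) and an at least 4.4-fold lower number from compound 1 to compound 4 (0.64 log units; beyond the scatter). The position is therefore not silent: with the shared core unchanged, exchanging this aryl group alone brings a value off the limit, which the 4-fluorophenyl, 4-bromophenyl and 4-nitrophenyl groups did not do. The steps among compound 1, compound 2 and compound 3 still cannot be read, and each new step has an open size on one side, because its starting value is only a limit: the limit of > 50000 nM in this assay, at which 3 of the 4 values shown sit.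

From the compounds shown here alone, it remains open whether the change follows the sulfamoyl group itself or its place on the phenyl ring, as 3-sulfamoylphenyl differs from the other three aryl groups in both respects. Going by these compounds, it is also open whether 4-sulfamoylphenyl, 3-aminophenyl or 3-carboxyphenyl at this position would give a lower number than compound 4 or return to the limit.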